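Swapping an Acetyl for a Silicon Group

A few compounds are considered here, and "the series" means these few. Any claim that something is new, unique, unknown or untested is made for them only; others in the source may bear on it.

In a functional assay on Col2 cells (Homo sapiens) for cytotoxicity, read by sulforhodamine B assay (a lower number here means that less compound is needed, a higher number that more compound is needed for the effect), compound 1 `C=C1CC[C@@H]2[C@](C)(COC(C)=O)[C@H](OC(C)=O)CC[C@@]2(C)[C@@H]1C/C=C1/C(=O)OC[C@H]1OC(C)=O` gives 10.8 uM. Compound 2 `C=C1CC[C@@H]2[C@](C)(CO[Si](c3ccccc3)(c3ccccc3)C(C)(C)C)[C@H](OC(C)=O)CC[C@@]2(C)[C@@H]1C/C=C1/C(=O)OC[C@H]1O` gives 3.8 uM. Among the compounds with values here, compound 1 thus holds the higher of the two numbers so far, and the gap to compound 2 lies beyond the usual scatter of repeated measurements.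

The next compound to be tested is compound 3 `C=C1CC[C@@H]2[C@](C)(CO[Si](C(C)C)(C(C)C)C(C)C)[C@H](OC(C)=O)CC[C@@]2(C)[C@@H]1C/C=C1/C(=O)OC[C@H]1OC(C)=O`, which departs from compound 1 by a single replacement: a group of 10 heavy atoms (9 carbon, 1 silicon; no ring) in place of a group of 3 heavy atoms (2 carbon, 1 oxygen; no ring), on an oxygen on a saturated carbon. An acetyl group leaves, and a larger group with silicon and no ring enters, on an oxygen on a saturated carbon.

Within the data shown here, no step between measured compounds isolates this change, so any expectation rests on thin evidence. Among the measured compounds shown here, the one pointer is compound 2, which also carries silicon and stands at 3.8 uM in this assay. A modest shift towards a lower number therefore seems more likely than none, though it may not clear the scatter. The estimated step is a 2.0-fold lower number from compound 1 to compound 3 (0.29 log units; within the scatter). Compound 3 is expected at 5.5 uM, with an estimated range from 2.2 uM to 13 uM.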

Compound 3, concentration for half-maximal effect: 13.6 uM
For compound 3 the middle estimate is 2.5-fold (0.39 log units) below the measured one, and the stated range ends below it.
By their numbers in this assay, from the lowest: compound 2; then compounds 1 and 3 (each within the scatter of the next).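

In this assay, replacing the acetyl on this oxygen with the larger silicon group gives a 1.3-fold higher number from compound 1 to compound 3 (0.10 log units; within the scatter) and so leaves the read-out within the scatter. Within the data shown here, this is the first comparison that changes a single place, and it shows that this oxygen on a saturated carbon can carry either the acetyl or a group of 10 heavy atoms with no change that the assay can separate from repeat variation; the presence of silicon at this position therefore does not by itself go with a lower number, and compound 2, which also carries silicon, differs from compound 3 in more than one place, so its lower number cannot be assigned to any one of its differences. Nothing measured here bears on why the acetyl and the silicon group read alike.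

The compounds shown leave open whether a free hydroxyl, a methyl ether or a benzoyl group on this same oxygen would read differently from the acetyl and the silicon group. They also leave open whether the silicon group with phenyl rings in compound 2 would, on its own and with every other part of compound 1 kept in place, move the number at all.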